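Step toward a 3,5-dimethoxyphenyl analogue in rat liver microsomes

The compounds below may be only part of what the source reports. "The series", "measured", "known", "first", "only" and "open" are said of these compounds alone.

Measured compounds:
- Compound 1, `C[C@H](c1ccccc1)N1C(=O)O[C@](Cc2ccccc2)(c2ncc(-c3ccccc3)[nH]2)C1=O`: 4%
- Compound 2, `C[C@H](c1ccccc1)N1C(=O)O[C@](Cc2ccccc2)(c2ncc(Cc3ccccc3)[nH]2)C1=O`: 0%

Two compounds have been run in an ADME assay (liver) for metabolic stability, with Liver microsome (Rattus norvegicus) as the target, using microsomes, with a stated time of 0.5 h, tested at 1 uM (a lower number here means that less of the compound is left, a higher number that more of the compound is left), so far. In this assay compound 1 gives 4%, and compound 2 gives 0%. Among the measured compounds shown here, the one step between them, a number 4 percentage points lower from compound 1 to compound 2 (within the scatter), is the only measured step on record, and it is within the scatter, so the two numbers cannot be told apart; both lie close to the bottom of the scale, where very little of the compound remains after the incubation.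

Compound 3, `COc1cc(OC)cc(-c2cnc([C@@]3(Cc4ccccc4)OC(=O)N([C@H](C)c4ccccc4)C3=O)[nH]2)c1`, is the next compound to be measured. It differs from compound 2 in one place: 3,5-dimethoxyphenyl in place of benzyl on an aromatic carbon. For the measured compounds named here, the only step that bears on this position is the one from compound 1 to compound 2, which was within the scatter, so there is no measured sign that changes at this aromatic carbon move the number much. Starting from a value at the floor of the scale, the step expected for compound 3, a number 3 percentage points higher from compound 2 to compound 3 (within the scatter), is small and within the scatter. Compound 3 is therefore estimated at 3%, with a range from 0% to 14%.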

Compound 3, percent of the compound remaining: 4%
Estimate against measurement, compound 3: 1 percentage points below, and the stated range covers the measured number.
By their numbers in this assay, from the lowest: compounds 2, 1 and 3 (each within the scatter of the next).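

In this assay the swap to 3,5-dimethoxyphenyl at this aromatic carbon of the five-membered ring gives a small step from either earlier group (a number 4 percentage points higher from compound 2 to compound 3 (within the scatter); no change at the digits printed from compound 1 to compound 3 (within the scatter)), so phenyl, benzyl and 3,5-dimethoxyphenyl cannot be told apart at this place. The earlier pair compared only groups made of carbon, whereas this group brings two oxygen atoms and two hydrogen-bond acceptors, and the read-out still lies near the bottom of the scale. Nothing at hand explains why so little of these compounds is left after the incubation.

On these data alone, all three groups at this carbon contain a six-membered aromatic ring of carbon only, so it remains open how an amine, a carboxylic acid or a longer chain would read at this place. As far as these compounds go, it also remains open whether any change to the shared core away from this carbon, such as replacing the benzyl group on the core with a smaller group, would leave more of the compound in the incubation.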